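The source may report more compounds than this note shows. Statements on the series, on what has been measured and on what is new or still open speak of the compounds shown alone.

For the measured compounds named here, compound 3, with the structure `COc1cccnc1Nc1cc2[nH]c(-c3cccc(C(F)(F)F)c3)nc2cn1`, stands at the top of the three numbers measured so far. In an ADME assay on microsomes from liver (Homo sapiens) for metabolic stability, read by LC-MS, with a stated time of 30 min, tested at 0.1 uM (a lower number here means that less of the compound is left, a higher number that more of the compound is left), compound 3 gives 69%, and compound 1, with the structure `FC(F)(F)c1cccc(-c2nc3cnc(Nc4ccccn4)cc3[nH]2)c1`, gives 69%, so the two are level at the digits shown; compound 2, with the structure `COc1cccc(Nc2cc3[nH]c(-c4cccc(C(F)(F)F)c4)nc3cn2)n1`, gives 45% and sits lowest. The step from compound 3 to compound 4 is 4-methoxypyridin-2-yl in place of 3-methoxypyridin-2-yl on a nitrogen on an aromatic ring, giving compound 4 the structure `COc1ccnc(Nc2cc3[nH]c(-c4cccc(C(F)(F)F)c4)nc3cn2)c1`. Going by the values given here, two measured steps bear on this: adding a methoxy to the pyridine gave no change at the digits printed from compound 1 to compound 3 (within the scatter) in one place but a number 24 percentage points lower from compound 1 to compound 2 (beyond the scatter) in another, and shifting the methoxy between those two places gave a number 24 percentage points higher from compound 2 to compound 3 (beyond the scatter). So where the methoxy sits on the pyridine can move this assay by a modest amount or leave it unchanged, and the new place in compound 4 has no measured counterpart. Because one of the two known placements gave a number 24 percentage points lower from compound 1 to compound 2 (beyond the scatter), compound 4 is expected to land somewhat lower than compound 3, a step of about a number 14 percentage points lower from compound 3 to compound 4 (beyond the scatter), though the scatter could swallow it. The estimate for compound 4 in this assay is 55%, within a range from 30% to 78%.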

Compound 4, percent of the compound remaining: 80%
The estimate for compound 4 lay 25 percentage points below the measured number; the whole stated range lies below it.
By their numbers in this assay, from the lowest: compound 2; then compounds 1 and 3 (each within the scatter of the next); then compound 4.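

For the compounds shown here, the 4-methoxypyridin-2-yl group is the first placement of the methoxy to stand clear of the other two in this assay, with a number 11 percentage points higher from compound 3 to compound 4 (beyond the scatter) and a number 35 percentage points higher from compound 2 to compound 4 (beyond the scatter) in the amount of compound left. Set against the ring without a methoxy, the same added group now gives a number 11 percentage points higher from compound 1 to compound 4 (beyond the scatter) at this placement, while the earlier placements gave no change at the digits printed from compound 1 to compound 3 (within the scatter) and a number 24 percentage points lower from compound 1 to compound 2 (beyond the scatter), so on this ring a single methoxy can leave the number unchanged, lower it or raise it, depending only on where it sits. Nothing shown here gives a measured reason for this dependence on placement.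

On these data alone, it remains open whether the gain belongs to the methoxy itself or would also appear with another group in its place on the 4-substituted pyridine, such as an ethoxy, a longer chain or an amine. These compounds also leave open whether the same ranking of placements would hold with a group other than trifluoromethyl on the far ring of the shared core.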